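This account rests on a few compounds, and the source may have more. Where it says the series, first, only, none or still open, it means among the compounds named here.

Working notes on the series.

Of the compounds shown here, three of a shared core have been measured. Compound 1 `Cc1ccc2c(c1)/C(=N/NC(=S)N1CCN(c3ccccc3)CC1)C(=O)N2` gives 9880 nM in a functional assay on A549 cells (Homo sapiens) for inhibition, read by MTT assay, with a stated time of 72 h; on this read-out higher numbers stand for weaker inhibition and lower numbers for stronger inhibition. Compound 2 `O=C1Nc2c(Br)cc(Br)cc2/C1=N/NC(=S)N1CCN(c2ccccc2)CC1` gives 6110 nM in this assay. Compound 3 `Cc1ccc(N2CCN(C(=S)N/N=C3\C(=O)Nc4ccc(Cl)cc43)CC2)cc1` gives 10100 nM in this assay. Compound 3 is the reference point for the step considered here; its number is the largest of the three as written, yet it is separated from compound 1 and from compound 2 by gaps that both fall within the usual scatter, so the three values are not distinguishable from one another on this read-out.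

Compound 4 `O=C1Nc2ccc(Cl)cc2/C1=N/NC(=S)N1CCN(c2ccc([N+](=O)[O-])cc2)CC1` has not been measured in this assay. It differs from compound 3 in one place: nitro in place of methyl on an aromatic carbon. The difference, cut one bond further out, reads 4-methylphenyl to 4-nitrophenyl. Going by the values given here, no measured pair in the set shows this exchange, so its effect has to be guessed from the spread of the three numbers alone, which is narrow.

The step from compound 3 to compound 4 in this assay is expected to be a 1.1-fold lower number from compound 3 to compound 4 (0.05 log units; within the scatter), no change beyond the scatter in either direction. Compound 4 is accordingly estimated at 9000 nM in this assay, with a range from 3500 nM to 25000 nM.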

Compound 4, half-maximal inhibitory concentration: 11800 nM
Compound 4: the middle estimate sits 1.3-fold (0.12 log units) below what was measured; measured number inside the range.
By their numbers in this assay, from the lowest: compounds 2, 1, 3 and 4 (each within the scatter of the next).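

In this assay, going by these compounds alone, the exchange of methyl for nitro on the aromatic carbon para to a large group gives a 1.2-fold higher number from compound 3 to compound 4 (0.07 log units; within the scatter), the first step that can be read between compounds differing in one place. The earlier compounds shown here showed nothing about this place on the 4-substituted phenyl group; this step shows that 3 heavy atoms with 2 hydrogen-bond acceptors can stand there in place of 1 heavy atom with none, without a change beyond the scatter. Nothing in hand bears on why this step stays within the scatter.

Whether an amine, a carboxylic acid or a longer chain at this place would leave the number equally unchanged remains open, since methyl and nitro are the only two groups shown there on this core. Also open, on these data alone, is whether the exchange of methyl for nitro would read the same on the cores of compound 1 and compound 2, which carry other groups on the shared core and an unsubstituted phenyl group.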